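A few compounds are considered here, and "the series" means these few. Any claim that something is new, unique, unknown or untested is made for them only; others in the source may bear on it.

Measured so far in a functional assay on HepG2 cells (Homo sapiens) for antiproliferative activity, read by MTT assay, with a stated time of 72 h; on this read-out higher numbers stand for weaker inhibition and lower numbers for stronger inhibition:
- compound 1 `O=C(N/N=C/c1cccc(Cl)c1Cl)Nc1ccc(Oc2ccnc3[nH]ccc23)cc1`: "not active" (no number reported)
- compound 2 `CN(C)CCn1cccc1/C=N/NC(=O)Nc1ccc(Oc2ccnc3[nH]ccc23)c(F)c1`: 8980 nM

Among the compounds with values here, compound 2 holds the only number, so it cannot yet be ranked against another numerical value. Compound 1 gives no number to compare with it.

The next compound is compound 3 `CN(C)CCn1cccc1/C=N/NC(=O)Nc1ccc(Oc2ccnc3[nH]ccc23)cc1`. The structural change from compound 2 is hydrogen in place of fluoro on an aromatic carbon. Within the data shown here, no measured pair shows the effect of this change, so the expectation has no direct precedent. In this assay, no step beyond the usual scatter is expected, and neither direction is favoured. Among the measured compounds shown here, the only anchor is compound 2 at 8980 nM. The expected step is a 1.0-fold higher number from compound 2 to compound 3 (0.00 log units; within the scatter). The estimated value for compound 3 is 9000 nM, within an expected range of 3500 nM to 23000 nM.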

Compound 3, half-maximal inhibitory concentration: "not active" (no number reported)
Compound 3: no number reported; the estimate stays without a comparison.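

In this assay, within the data shown here, compound 3 gives "not active" (no number reported) and so no step from compound 2 at 8980 nM can be read. The compounds shown leave open how hydrogen in place of fluoro shifts the number in this series. No available evidence bears on this result.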